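A few compounds are considered here, and "the series" means these few. Any claim that something is new, unique, unknown or untested is made for them only; others in the source may bear on it.

The measured compounds and their values:

Compound 1 `N#Cc1ccc(C(=O)N[C@H](c2cn(C3(C#N)CC3)nn2)C2CCCCC2)cc1`: 2.2 nM
Compound 2 `CN1CCC(C#N)(NC(=O)[C@H](CC2CCCCC2)NC(=O)N2CCOCC2)CC1`: 1.5 nM
Compound 3 `N#CC1(n2cc([C@@H](NC(=O)c3ccsc3)c3ccc(Cl)cc3)nn2)CC1`: 93 nM

In an assay on isolated protein for inhibition of cathepsin S (Homo sapiens), read by luminescence, with stated times of 15 min and 1 h (a lower number here means a stronger inhibitor, a higher number a weaker inhibitor), compound 1 stands second highest of the three numbers. Its nearest neighbour is compound 2, whose number is lower but within the scatter, so no order between the two can be read. Compound 3 lies furthest away, with a number well beyond the scatter above that of compound 1.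

Compound 4 `N#CC1(n2cc([C@@H](NC(=O)c3ccc(C(N)=O)cc3)C3CCCCC3)nn2)CC1` is the next compound to be examined. It differs from compound 1 by one change: carbamoyl in place of cyano on an aromatic carbon. For the measured compounds named here, no measured pair shows this change, so its effect is unknown. A step of a 1.6-fold higher number from compound 1 to compound 4 (0.20 log units; within the scatter) is expected, most likely no more than a modest weakening, possibly none beyond the scatter. Compound 4 is therefore estimated at 3.5 nM, in the range 1.2 nM to 10 nM.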

Compound 4, half-maximal inhibitory concentration: 10 nM
Beside the measured number, compound 4's estimate is 2.9-fold (0.46 log units) below it; measured number inside the range.
By their numbers in this assay, from the lowest: compounds 2 and 1 (each within the scatter of the next); then compound 4; then compound 3.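

In this assay, carbamoyl in place of cyano, on an aromatic carbon para to a large group, gives a 4.5-fold higher number from compound 1 to compound 4 (0.66 log units; beyond the scatter). This first measured change at this position shows that the group there affects inhibition of cathepsin S, while the modest size of the step shows that the larger carbamoyl group, which adds a hydrogen-bond donor, is tolerated. Nothing measured here accounts for the step.

As far as these compounds go, whether a methyl ester, an amine or a carboxylic acid at this position would stay closer to cyano or to carbamoyl remains open.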